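Ring-nitrogen substituent series: removing the aryl group

A few compounds are considered here, and "the series" means these few. Any claim that something is new, unique, unknown or untested is made for them only; others in the source may bear on it.

Measured so far in a functional assay on CCRF-CEM cells (Homo sapiens) for cytotoxicity, read by cell counting, with a stated time of 3 days; on this read-out lower numbers stand for stronger inhibition and higher numbers for weaker inhibition:
- compound 1 `Nc1ccc(/C=C2\SC(=O)N(Cc3cccc(F)c3)C2=O)cc1`: 116000 nM
- compound 2 `Nc1ccc(/C=C2\SC(=O)N(Cc3ccccc3)C2=O)cc1`: 42000 nM
- compound 3 `Nc1ccc(/C=C2\SC(=O)N(Cc3cccc(Cl)c3)C2=O)cc1`: 18000 nM

Compound 3 gives the lowest number of the three. Its separation from compound 2 is a 2.3-fold lower number from compound 2 to compound 3 (0.37 log units; beyond the scatter) and from compound 1 is a 6.4-fold lower number from compound 1 to compound 3 (0.81 log units; beyond the scatter), both beyond the scatter; compound 1 and compound 2 are separated by a 2.8-fold lower number from compound 1 to compound 2 (0.44 log units; beyond the scatter). The three compounds share the core of compound 3 and differ only in what sits on the aromatic ring attached to the ring nitrogen through the saturated chain carbon.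

Compound 4 `CN1C(=O)S/C(=C\c2ccc(N)cc2)C1=O` goes further: hydrogen in place of 3-chlorophenyl on a saturated chain carbon bound to an amide-type nitrogen in a ring. Among the measured compounds shown here, none of the measured steps removes the whole ring, so the closest guidance is indirect. The steps show that the identity of the substituent on that ring moves the number in this assay by modest amounts, and compound 3, carrying chloro, is the best of the three. Removing the ring entirely is expected to cost more than the step from compound 3 to compound 2, so a rise beyond the scatter is expected, a 5.0-fold higher number from compound 3 to compound 4 (0.70 log units; beyond the scatter). Compound 4 is estimated at 90000 nM, with a range of 25000 nM to 350000 nM.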

Compound 4, half-maximal inhibitory concentration: 62000 nM
Beside the measured number, compound 4's estimate is 1.5-fold (0.16 log units) above it; the range from low to high includes it.
By their numbers in this assay, from the lowest: compound 3; then compounds 2, 4 and 1 (each within the scatter of the next, the first and the last beyond it).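

In this assay, a 3.4-fold higher number from compound 3 to compound 4 (0.54 log units; beyond the scatter) is the only replacement of the aryl group by hydrogen that reads beyond the scatter. With a 1.5-fold higher number from compound 2 to compound 4 (0.17 log units; within the scatter) and a 1.9-fold lower number from compound 1 to compound 4 (0.27 log units; within the scatter) both within the scatter, the phenyl and 3-fluorophenyl groups at this position cannot be told from hydrogen, so among these compounds only the 3-chlorophenyl group separates from hydrogen, and the aryl ring alone does not set the number. Nothing available here gives a reason for this difference. 

Still open, going by these compounds, is whether a longer chain on the ring nitrogen, or a chain ending in an amine or a carboxylic acid, would separate from compound 4. Also open, on these data alone, is whether bromo in place of chloro would keep the separation seen with compound 3.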